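Removing the Trifluoromethyl Group from a Bicyclic Urea

The source may report more compounds than this note shows. Statements on the series, on what has been measured and on what is new or still open speak of the compounds shown alone.

Compound 1 `C[C@@H]1CN(Cc2ccccc2)c2nc(C(F)(F)F)ccc2[C@H](C)N1C(=O)NCc1ccccc1` was tested in an assay on HEK293 cells for inhibition of Voltage-dependent T-type calcium channel subunit alpha-1I (Homo sapiens), read by FLIPR and calcium flux, with a stated time of 3 min (a higher number here means a weaker inhibitor, a lower number a stronger inhibitor), where compound 1 gives 281 nM. Of the two numbers shown, that of compound 1 is the highest. Its nearest neighbour is compound 2 `COc1ccc(CNC(=O)N2[C@H](C)CN(CCC(C)C)c3cnccc3[C@@H]2C)cc1`, which in this assay gives 25 nM, a gap that lies beyond the usual scatter. Compound 3 `C[C@@H]1CN(Cc2ccccc2)c2c(cnn2C)[C@H](C)N1C(=O)NCc1ccccc1` reaches only > 10000 nM in this assay, which is a limit of the measurement and not a number. Compound 3 thus sits at the limit of > 10000 nM in this assay, at which 1 of the 3 values shown sits.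

Compound 4 `C[C@@H]1CN(Cc2ccccc2)c2ncccc2[C@H](C)N1C(=O)NCc1ccccc1` has not yet been measured. It differs from compound 1 by hydrogen in place of trifluoromethyl on an aromatic carbon. Among the measured compounds shown here, no measured pair shows this same change, so the size of the step is open; a small shift toward a weaker inhibitor, perhaps not beyond the scatter, seems plausible. Compound 4 is expected in this assay to give 500 nM, with a range from 150 nM to 2500 nM. The step of a 1.8-fold higher number from compound 1 to compound 4 (0.25 log units; within the scatter) is therefore expected to be modest.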

Compound 4, half-maximal inhibitory concentration: 8 nM
The estimate for compound 4 lay 63-fold (1.80 log units) above the measured number; measured number outside the range, below it.
By their numbers in this assay, from the lowest: compound 4; then compound 2; then compound 1. At a limit, above all of these: compound 3.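

In this assay, hydrogen in place of trifluoromethyl on this aromatic carbon, next to the ring nitrogen, gives a 35-fold lower number from compound 1 to compound 4 (1.55 log units; beyond the scatter). The trifluoromethyl group is therefore not required for inhibition on the core of compound 1, and on this core its presence goes with the much weaker number. The earlier compounds shown here differ from one another in more than one place, so they could not show this; the present pair is the only one that isolates this position, and nothing measured here bears on the size of the step.

With only hydrogen and trifluoromethyl shown at this carbon, it remains open how a methyl group, a chlorine or an amine would compare there. As far as these compounds go, it is also open whether the same step would appear with a different group in place of either benzyl group.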